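Compound 2 and the step to a dimethyl lactam

The source may report more compounds than this note shows. Statements on the series, on what has been measured and on what is new or still open speak of the compounds shown alone.

Measured compounds in a toxicity assay on HepG2 2.2.15 cells (Homo sapiens) for cytotoxicity, read by CellTiter-Glo; on this read-out higher numbers stand for lower toxicity in this test and lower numbers for higher toxicity in this test
compound 1 `O=C1CC(Oc2ncccn2)CN1c1cnn2c1CN(C(=O)Nc1cc(F)c(F)c(F)c1)C(C1CC1)C2` gives > 200000 nM
compound 2 `N#CC1CC(=O)N(c2cnn3c2CN(C(=O)Nc2cc(F)c(F)c(F)c2)C(C2CC2)C3)C1` gives > 200000 nM
compound 3 `O=C1CC(c2cnc(C(F)(F)F)s2)CN1c1cnn2c1CN(C(=O)Nc1cc(F)c(F)c(F)c1)C(C1CC1)C2` gives 38500 nM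

Compound 2 stands at > 200000 nM, which is a limit of the assay and not a number. That is the limit of > 200000 nM in this assay, at which 2 of the 3 values shown sit. The next compound, compound 4 `CC1(C)CC(=O)N(c2cnn3c2CN(C(=O)Nc2cc(F)c(F)c(F)c2)C(C2CC2)C3)C1`, carries 4,4-dimethyl-2-oxopyrrolidin-1-yl in place of 4-cyano-2-oxopyrrolidin-1-yl on an aromatic carbon. Among the measured compounds shown here, three measured steps bear on this change, since each alters the same saturated ring carbon. The first, a step that the two limits leave unreadable from compound 1 to compound 2, gives no guidance. For the measured compounds named here, the other two, an at least 5.1-fold lower number from compound 1 to compound 3 (0.71 log units; beyond the scatter) and an at least 5.1-fold lower number from compound 2 to compound 3 (0.71 log units; beyond the scatter), both lead to compound 3, the only compound with a number. On those two steps, a drop of modest size or less is expected in this assay, and a result at the limit remains quite possible. The expected step is an at least 1.6-fold lower number from compound 2 to compound 4 (0.22 log units; that floor lies within the scatter). For compound 4 the estimated value is 120000 nM, with an expected range from 40000 nM to 250000 nM.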

Compound 4, half-maximal cytotoxic concentration: 115000 nM
Compound 4: the middle estimate sits 1.0-fold (0.02 log units) above what was measured, and the stated range covers the measured number.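

In this assay, compound 4 gives 115000 nM, so this series now has a second number beside compound 3, which gives 38500 nM, and this one comes from a lactam with no aromatic group on its saturated ring carbon. Putting 4,4-dimethyl-2-oxopyrrolidin-1-yl on this aromatic carbon gives an at least 1.7-fold lower number from compound 2 to compound 4 (0.24 log units; that floor lies within the scatter), so the compounds do not establish a change beyond the scatter. Compound 2 stands at a limit of the assay and not at a number, which leaves the true size of this step unfixed: the limit of > 200000 nM in this assay, at which 2 of the 4 values shown sit.

What the compounds shown leave open is how an amine or a carboxylic acid on this saturated ring carbon would read in this assay. Also open, on these data alone, is whether a single methyl or a longer chain there would sit near compound 4 or reach the limit seen for compound 2.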